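Urea series: adding a second fluoro substituent

The source may hold more compounds than are shown below. What is called first, only, known or untested is meant among the compounds shown, and "the series" means these compounds.

Measured so far:
- compound 1, `CC(=O)c1cccc(NC(=O)N[C@H](C)c2ccccc2)c1`: 98%
- compound 2, `C[C@@H](NC(=O)Nc1cccc(F)c1)c1ccccc1`: 99%

Both measured compounds were tested in an ADME assay on the whole organism with Oryza sativa as the target, tested at 0.1 uM; a higher number here means a weaker effect of the compound at the concentration tested, a lower number a stronger effect. Compound 1 gives 98% and compound 2 gives 99%; the step of a number 1 percentage points higher from compound 1 to compound 2 (within the scatter) is within the scatter, so on the numbers shown the two cannot be told apart and both show almost no effect at the tested concentration. Compound 2 stands at the higher of the two values, but with its nearest neighbour, compound 1, within the scatter of it.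

Compound 3, `C[C@@H](NC(=O)Nc1cc(F)cc(F)c1)c1ccccc1`, has not yet been measured. It differs from compound 2 by fluoro in place of hydrogen on an aromatic carbon.

Among the measured compounds shown here, no measured step describes the addition of a fluoro group at this position; the only step known, a number 1 percentage points higher from compound 1 to compound 2 (within the scatter), exchanges one group for another on an aromatic carbon and stays within the scatter. Both measured compounds sit at the top of the read-out range, so there is little room for a higher number. The expected step of a number 1 percentage points lower from compound 2 to compound 3 (within the scatter) is therefore none beyond the scatter. The estimate for compound 3 in this assay is 98%, with a range from 91% to 100%.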

Compound 3, a percentage reported as activity, at one concentration (the size of the read-out at that concentration, not a potency): 98%
Beside the measured number, compound 3's estimate shows no gap at the digits printed; the range from low to high includes it.
By their numbers in this assay, from the lowest: compounds 1, 3 and 2 (each within the scatter of the next).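

In this assay, putting a second fluoro group on the six-membered aromatic ring, meta to a fluoro group and meta to a large group, gives a number 1 percentage points lower from compound 2 to compound 3 (within the scatter) and so does not move the read-out beyond the scatter. Among the compounds shown here, this is the first step that sets fluoro against hydrogen on an aromatic carbon, whereas a number 1 percentage points higher from compound 1 to compound 2 (within the scatter) only exchanged one group for another, and neither step can be told from the scatter. The data at hand offer nothing that bears on why this change leaves the read-out within the scatter.

With every read-out here taken at a single concentration and compound 3 close to the weak end of the range, these numbers leave open whether the fluoro group has any effect that a stronger-acting member of the series could reveal. Going by these compounds, it also remains open whether a different group at this position, such as an amine, a carboxylic acid or a longer chain, would give a step beyond the scatter.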